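The compounds below may be only part of what the source reports. "The series", "measured", "known", "first", "only" and "open" are said of these compounds alone.

Measured in a functional assay on MDA-MB-231 cells (Homo sapiens) for antiproliferative activity, read by sulforhodamine B assay; a lower number here means a stronger inhibitor of growth, a higher number a weaker inhibitor of growth:
- Compound 1 `O=C(/C=C/c1ccc(O)cc1)c1c(O)cccc1OCCC1CCCCC1`: > 30000 nM (a limit)
- Compound 2 `O=C(/C=C/c1ccc(O)cc1)c1c(O)cccc1OCC1CCCCC1`: > 30000 nM (a limit)
- Compound 3 `CC(C)CCOc1cccc(O)c1C(=O)/C=C/c1ccc(O)cc1`: 10300 nM

Going by the values given here, compound 3 is the only compound here with a true number, 10300 nM. Compound 1 and compound 2 reach only (the limit of > 30000 nM in this assay, at which 2 of the 3 values shown sit).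

Compound 4 `O=C(/C=C/c1ccc(O)cc1)c1c(O)cccc1OCc1ccccc1` keeps the shared core and differs from compound 3 in one place: phenyl in place of isobutyl on a saturated chain carbon bound to an oxygen on an aromatic ring. Read one bond further out, isopentyloxy becomes benzyloxy.

The closest guide is an at least 2.9-fold lower number from compound 2 to compound 3 (0.46 log units; beyond the scatter), where isobutyl replaced cyclohexyl at this same place. an at least 2.9-fold lower number from compound 1 to compound 3 (0.46 log units; beyond the scatter) points the same way, while a step that the two limits leave unreadable from compound 1 to compound 2 adds nothing. Among the compounds with values here, compound 4 also carries a six-membered ring there, so a modest move to a higher number is expected, although phenyl is not cyclohexyl and no measured compound has phenyl at this place. The expected change is a 1.9-fold higher number from compound 3 to compound 4 (0.29 log units; within the scatter). A result reported only as a limit is also quite possible. For compound 4 the estimate is 20000 nM, with an expected range of 8000 nM to 30000 nM.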

Compound 4, concentration for 50% growth inhibition: > 30000 nM
Compound 4: no number, only a limit; the forecaster's own chance of this, stated with the estimate: 45%; at least 1.5-fold (0.17 log units) between middle value and limit.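

In this assay, phenyl in place of isobutyl on this saturated chain carbon gives an at least 2.9-fold higher number from compound 3 to compound 4 (0.46 log units; beyond the scatter), so the higher number seen with the saturated cyclohexyl ring also appears with an aromatic ring. Among the compounds shown, only compound 3, which has no ring in this side chain, gives a true number, and nothing among them goes against this pattern. Compound 4 is reported only as a limit, the steps to it from compound 1 and compound 2 cannot be read, and the ring-bearing compounds therefore cannot be ranked, as all sit at one line: the limit of > 30000 nM in this assay, at which 3 of the 4 values shown sit.

As far as these compounds go, whether a smaller ring, such as cyclopropyl, would give a true number at this place remains open. From the compounds shown here alone, it is also open how a shorter ethyl chain, a longer hexyl chain or an amine at the chain end would compare with compound 3.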